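Adding a Methoxy Group: Expectation for Compound 4

A few compounds are considered here, and "the series" means these few. Any claim that something is new, unique, unknown or untested is made for them only; others in the source may bear on it.

Measured so far:
compound 1 `COc1ccc(-c2cc(/C=C/C(=O)c3ccc(N)cc3)[nH]n2)cc1` 105%
compound 2 `COc1ccc(C(=O)/C=C/c2cc(-c3cc(OC)c(OC)c(OC)c3)n[nH]2)cc1OC` 96%
compound 3 `COc1ccc(-c2cc(/C=C/C(=O)c3ccc(N)cc3)[nH]n2)cc1OC` 90%

In a functional assay on OVCAR-4 cells (Homo sapiens) for cytotoxicity, read by sulforhodamine B assay, with a stated time of 48 h, tested at 0.1 uM (a lower number here means a stronger effect, a higher number a weaker effect of the compound at the concentration tested), compound 1 gives 105% and compound 3 gives 90%. The change between them is methoxy in place of hydrogen on an aromatic carbon, and it made a step of a number 15 percentage points lower from compound 1 to compound 3 (beyond the scatter). Compound 2 gives 96% in this assay; the difference between its core and the core of compound 1 is not broken down here, and its value lies within the scatter of compound 3 and of compound 1.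

Compound 4 `COc1cc(C(=O)/C=C/c2cc(-c3cc(OC)c(OC)c(OC)c3)n[nH]2)cc(OC)c1OC` has not yet been measured. It differs from compound 2 by methoxy in place of hydrogen on an aromatic carbon. This is the same kind of change as from compound 1 to compound 3, but the surroundings differ: in compound 4 the entering methoxy is also meta to a methoxy group. A step of a number 11 percentage points lower from compound 2 to compound 4 (beyond the scatter) is expected in this assay, resting on a number 15 percentage points lower from compound 1 to compound 3 (beyond the scatter), tempered since the surroundings are not identical. Compound 4 is therefore estimated at 85%, between 65% and 105%.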

Compound 4, a percentage reported as activity, at one concentration (the size of the read-out at that concentration, not a potency): 95%
Compound 4: middle estimate off by 10 percentage points, on the low side; low and high end bracket the measured number.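

In this assay, within the data shown here, methoxy in place of hydrogen on an aromatic carbon gives a number 1 percentage points lower from compound 2 to compound 4 (within the scatter), so on this core the change leaves no step that can be told from the usual scatter. Set beside the earlier step, the two results do not differ by more than such pairs of steps normally would: the same change on two cores in this assay, a number 15 percentage points lower (beyond the scatter) from compound 1 to compound 3 and a number 1 percentage points lower (within the scatter) from compound 2 to compound 4, 14 percentage points apart, within the scatter of two such steps This means the data do not show that the core alters the effect of the change, but they do not show that its size carries over from one core to the other either, since there is only one step on each core and one of them is within the scatter.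

The compounds shown leave open whether a different group in place of that hydrogen, such as a hydroxyl, a chlorine or a carboxylic acid, would give a clear step on both cores. They also leave open whether a longer chain, such as ethoxy in place of methoxy, would behave any differently.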